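Swapping the Aminoethyl Chain for Isopropyl on the Ether Oxygen

The compounds below may be only part of what the source reports. "The series", "measured", "known", "first", "only" and "open" are said of these compounds alone.

Of the compounds shown here, two have been measured so far in an assay on cells for inhibition of MAP kinase-interacting serine/threonine-protein kinase 1 (Homo sapiens), read by mobility shift assay, with stated times of 10 min and 60 min, in the presence of a further agent that is not named here; a higher number here means a weaker inhibitor, a lower number a stronger inhibitor. Compound 1 `Cc1[nH]ncc1-c1cncc(-c2ccc(C(N)=O)c(OC(C)C)c2)c1` gives 54 nM in this assay. Compound 2 `NCCOc1cc(-c2cccnc2)ccc1C(N)=O` gives 820 nM, which is the higher of the two numbers, and the gap between compound 2 and compound 1 lies beyond the usual scatter of repeated measurements. Compound 1 carries an isopropyl group on the ether oxygen of its shared core, whereas compound 2 carries a 2-aminoethyl chain there; compound 1 also bears an additional methyl-substituted pyrazole ring that compound 2 lacks.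

Compound 3 `CC(C)Oc1cc(-c2cccnc2)ccc1C(N)=O` has not yet been measured. It is compound 2 with one change: isopropyl in place of 2-aminoethyl on an oxygen on an aromatic ring. In this way compound 3 matches compound 1 at the ether oxygen while keeping the simpler pyridine of compound 2.

Because compound 1, which shares this isopropyl group, gives 54 nM, the expectation is that compound 3 lands at a lower number than compound 2, though the extra ring in compound 1 leaves the size of that improvement uncertain. The step expected from compound 2 to compound 3 is a 2.7-fold lower number from compound 2 to compound 3 (0.44 log units; beyond the scatter). For compound 3 the estimated value is 300 nM, with a likely range from 90 nM to 1200 nM.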

Compound 3, half-maximal inhibitory concentration: 880 nM
Beside the measured number, compound 3's estimate is 2.9-fold (0.47 log units) below it; the measured number falls inside the stated range.
By their numbers in this assay, from the lowest: compound 1; then compounds 2 and 3 (each within the scatter of the next).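

In this assay, isopropyl in place of 2-aminoethyl on an oxygen on an aromatic ring gives a 1.1-fold higher number from compound 2 to compound 3 (0.03 log units; within the scatter), so on this simpler core the two groups cannot be told apart, even though 2-aminoethyl counts one hydrogen-bond donor and one acceptor and isopropyl counts none. The large difference lies at the other site: hydrogen in place of 5-methyl-1H-pyrazol-4-yl on an aromatic carbon corresponds, read in reverse, to a 16-fold higher number from compound 1 to compound 3 (1.21 log units; beyond the scatter), which ties the lower number of compound 1 to that ring rather than to the isopropyl group on the oxygen. Nothing measured here explains either result.

Whether 2-aminoethyl and isopropyl also match when 5-methyl-1H-pyrazol-4-yl is present remains open, since the compounds shown carry only isopropyl on that fuller core. Also open, going by these compounds, are how a longer chain, an amine with a ring or a carboxylic acid would read on the ether oxygen, and whether a pyrazole without its methyl group would hold the lower number of compound 1.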